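Swapping Azido for Methylsulfanyl on Two Related Sugar Cores

A few compounds are considered here, and "the series" means these few. Any claim that something is new, unique, unknown or untested is made for them only; others in the source may bear on it.

Among the measured compounds shown here, the first pair of compounds shows the effect of one small exchange. Compound 1 `CC(=O)OC1C(CN=[N+]=[N-])OC(n2c(Cl)nc3cc(Cl)c(Cl)cc32)C1OC(C)=O` carries an azido group on a saturated chain carbon bound to a saturated ring carbon, and in a functional assay on KB cells (Homo sapiens) for inhibition (a lower number here means a stronger inhibitor, a higher number a weaker inhibitor), compound 1 gives 70000 nM. Compound 2 `CSCC1OC(n2c(Cl)nc3cc(Cl)c(Cl)cc32)C(OC(C)=O)C1OC(C)=O` is built the same way except for the exchange (methylsulfanyl in place of azido on a saturated chain carbon bound to a saturated ring carbon). In this assay compound 2 gives 70000 nM, so the measured step is no change at the digits printed from compound 1 to compound 2 (within the scatter).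

Compound 3 `[N-]=[N+]=NC[C@H]1OC(n2c(Cl)nc3cc(Cl)c(Cl)cc32)[C@H](O)[C@@H]1O` carries the same azido group on the same kind of position, but its core differs from the core of compound 1 in more than one place; that difference between the two cores is not broken down here. In this assay compound 3 gives 70000 nM, a value that sits within the usual scatter of both compound 1 and compound 2.

Compound 4 `CSC[C@H]1OC(n2c(Cl)nc3cc(Cl)c(Cl)cc32)[C@H](O)[C@@H]1O` is not yet measured. It arises from compound 3 by the exchange (methylsulfanyl in place of azido on a saturated chain carbon bound to a saturated ring carbon), and the place of the exchange is described in the same words as for the pair of compound 1 and compound 2, so it is the same change on a different core. The expected step in this assay is no change at the digits printed from compound 3 to compound 4 (within the scatter), resting on the earlier step of no change at the digits printed from compound 1 to compound 2 (within the scatter) that produced no shift. Compound 4 is therefore estimated at 70000 nM, with a likely range from 35000 nM to 140000 nM.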

Compound 4, half-maximal inhibitory concentration: > 100000 nM
Compound 4 gave a limit, no number; the forecaster's own chance of this, stated with the estimate: 40%; middle value at least 1.4-fold (0.15 log units) away from the limit.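

In this assay compound 4 gives > 100000 nM, which is a limit of the assay and not a number. Exchanging azido for methylsulfanyl on this second core therefore gives an at least 1.4-fold higher number from compound 3 to compound 4 (0.15 log units; that floor lies within the scatter), and the comparison with the same exchange on the first core reads: the same change on two cores in this assay, no change at the digits printed (within the scatter) from compound 1 to compound 2 and an at least 1.4-fold higher number (0.15 log units; that floor lies within the scatter) from compound 3 to compound 4; the limit leaves it open whether they differ. This shows that the exchange gave no measured gain in inhibition on either core, but it does not show that the exchange acts alike on the two cores, nor that it acts differently, as one of the two steps has only a floor and no measured size.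

The compounds shown leave open how far past its limit compound 4 really lies, and whether the exchange would carry over in the same way on a core whose values sit well clear of that limit. They also leave open what other groups on a saturated chain carbon bound to a saturated ring carbon, such as an amine, a carboxylic acid or a longer chain, would give in this assay.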